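Swapping fluoro for nitro on a shared core

A few compounds are considered here, and "the series" means these few. Any claim that something is new, unique, unknown or untested is made for them only; others in the source may bear on it.

Compound 1 `O=C1Nc2ccc(F)cc2/C1=C\C(=O)c1ccc(O)cc1F` gives 1070 nM
Compound 2 `O=C1Nc2ccc(F)cc2/C1=C\C(=O)c1ccc(C2CCCCC2)cc1` gives 2520 nM

Both values come from a functional assay on HCT-116 cells (Homo sapiens) for inhibition, read by sulforhodamine B assay, with a stated time of 3 days (a lower number here means a stronger inhibitor, a higher number a weaker inhibitor), and they differ beyond the usual scatter. Compound 2 has the higher number of the two, which makes it the weaker inhibitor. Compound 3 `O=C1Nc2ccc([N+](=O)[O-])cc2/C1=C\C(=O)c1ccc(C2CCCCC2)cc1` is not yet measured. It carries nitro in place of fluoro on an aromatic carbon of compound 2. Among the measured compounds shown here, no measured pair shows this change, so the data offer little guidance on size or direction. The expected step of a 1.3-fold lower number from compound 2 to compound 3 (0.10 log units; within the scatter) stays within the scatter. Compound 3 is estimated at 2000 nM (expected range 700 nM to 6000 nM).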

Compound 3, half-maximal inhibitory concentration: 2320 nM
Compound 3: middle estimate off by 1.2-fold (0.06 log units), on the low side, within the range that was stated.
By their numbers in this assay, from the lowest: compound 1; then compounds 3 and 2 (each within the scatter of the next).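

Replacing fluoro with nitro on this aromatic carbon of the shared core gives a 1.1-fold lower number from compound 2 to compound 3 (0.04 log units; within the scatter) in this assay and leaves the two compounds within the usual scatter. This first single-change pair shows that, with the cyclohexyl-bearing side of the molecule held constant, this position accepts three heavy atoms in place of one without a difference that can be read. No measurement here offers an explanation. Going by these compounds, whether an amine or a carboxylic acid on the same carbon would also stay within the scatter remains open.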